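Trifluoromethoxy for Trifluoromethyl on Two Urea Cores

The source may hold more compounds than are shown below. What is called first, only, known or untested is meant among the compounds shown, and "the series" means these compounds.

Compound 1 `O=C(Nc1ccc(C(F)(F)F)cc1)N1CCN(c2ccc(-c3ccccc3)nn2)CC1` gives > 10000 nM in an assay on HEK293 cells for inhibition of transient receptor potential cation channel subfamily V member 1 (Homo sapiens), read by FLIPR; on this read-out lower numbers stand for stronger inhibition and higher numbers for weaker inhibition.
Compound 2 `O=C(Nc1ccc(OC(F)(F)F)cc1)N1CCN(c2ccc(-c3ccccc3)nn2)CC1` gives > 10000 nM in this assay.
Compound 3 `O=C(Nc1ccc(C(F)(F)F)cc1)N1CCN(c2nncc3ccccc23)CC1` gives > 10000 nM in this assay.

Each of these three values is a limit of this assay, not a measured number. The value of compound 1 is a limit. The value of compound 2 is a limit. The value of compound 3 is a limit. All three sit at the same limit (the limit of > 10000 nM in this assay, at which 3 of the 3 values shown sit), so none of them can be ranked against another.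

Compound 1 and compound 2 share one core and differ in one place: trifluoromethoxy in place of trifluoromethyl on an aromatic carbon. The step this change made, a step that the two limits leave unreadable from compound 1 to compound 2, cannot be read, since both ends are limits.

Compound 3 carries another core; the difference between the two cores is not broken down here. Compound 4 `O=C(Nc1ccc(OC(F)(F)F)cc1)N1CCN(c2nncc3ccccc23)CC1` has not yet been measured in this assay. It differs from compound 3 by trifluoromethoxy in place of trifluoromethyl on an aromatic carbon, the same change that leads from compound 1 to compound 2, at a place described in the same words.

Because compound 3 gives > 10000 nM and the same change on compound 1 gave a step that the two limits leave unreadable from compound 1 to compound 2, the step for compound 4 is expected to be a step that the limit leaves unreadable from compound 3 to compound 4. Compound 4 is therefore expected to give about 15000 nM, most likely again reported only as a limit, within a range from 5000 nM to 50000 nM.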

Compound 4, half-maximal inhibitory concentration: > 10000 nM
Compound 4 gave a limit, no number; the forecaster's own chance of this, stated with the estimate: 85%; the middle value is on the limit's open side.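

In this assay compound 4 gives > 10000 nM, which is a limit and not a number. Compound 3 also stands at a limit, so the step between compound 3 and compound 4 cannot be read, and no new comparison arises: the limit of > 10000 nM in this assay, at which 4 of the 4 values shown sit. The compounds shown leave open how strongly any of the four inhibits in this assay, and whether trifluoromethoxy in place of trifluoromethyl changes that on either core.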